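From bromo to methylsulfanyl at the weak end

The compounds below may be only part of what the source reports. "The series", "measured", "known", "first", "only" and "open" are said of these compounds alone.

Measured so far in a functional assay on L1210 cells (Mus musculus); a higher number here means a weaker inhibitor, a lower number a stronger inhibitor:
Compound 1 `O[C@@H]1[C@@H](CF)OC(n2c(Cl)nc3cc(Cl)c(Cl)cc32)[C@@H]1O` gives > 100000 nM as a limit
Compound 2 `O[C@@H]1[C@@H](CBr)OC(n2c(Cl)nc3cc(Cl)c(Cl)cc32)[C@@H]1O` gives 100000 nM as a number

Compound 2 stands at 100000 nM as the only true number shown so far. Compound 3 `CSC[C@H]1OC(n2c(Cl)nc3cc(Cl)c(Cl)cc32)[C@H](O)[C@@H]1O` carries methylsulfanyl in place of bromo on a saturated chain carbon bound to a saturated ring carbon as its change, methylsulfanyl in place of bromo on a saturated chain carbon bound to a saturated ring carbon. Within the data shown here, one measured step bears on this place: a number no higher from compound 1 to compound 2 (the limit leaves the size open) is what bromo in place of fluoro gave, and its size stays open. It therefore offers no firm size to carry over. No shift beyond the scatter is expected in this assay for this change. The expected step is no change at the digits printed from compound 2 to compound 3 (within the scatter) on this estimate. For compound 3 the estimated value is 100000 nM with an expected span from 40000 nM to 200000 nM as its range.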

Compound 3, half-maximal inhibitory concentration: > 100000 nM
Compound 3 gave a limit, no number (the forecaster's own chance of this, stated with the estimate: 50%); the middle value lies on the limit itself.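

In this assay compound 3 gives > 100000 nM, which is a limit of the assay and not a number. Methylsulfanyl in place of bromo gives a number no lower from compound 2 to compound 3 (the limit leaves the size open), so neither fluoro nor methylsulfanyl on this saturated chain carbon gives a lower number than compound 2, while the step from compound 1 to compound 3 joins two limits and cannot be read. The compounds shown thus stay at the weak end of the read-out, and most of them give no number at all: the limit of > 100000 nM in this assay, at which 2 of the 3 values shown sit.

As far as these compounds go, how far compound 1 and compound 3 lie past that limit stays open. Also open, from the compounds shown here alone, is how an amine, a carboxylic acid or a longer chain at this place would read in this assay.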